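A few compounds are considered here, and "the series" means these few. Any claim that something is new, unique, unknown or untested is made for them only; others in the source may bear on it.

Measured set:
compound 1 `O=c1[nH]c(=O)n([C@H]2C[C@H](O)[C@@H](CO)O2)cc1C#CCO` — in an ADME assay on L1210/0 cells (Mus musculus) for cytotoxicity, with a stated time of 48 h; a lower number here means a stronger inhibitor, a higher number a weaker inhibitor: > 200000 nM
compound 2 `Nc1ccn(C[C@@H]2C[C@H](CO)c3ccccc32)c(=O)n1` — in this assay: > 200000 nM
compound 3 `Nc1ncnc2c1ncn2C1OC(/C=N/O)CC1O` — in this assay: > 200000 nM

Compound 1 reaches only a limit of this assay, not a number. Compound 2 likewise sits at a limit. Compound 3 also sits at a limit. the limit of > 200000 nM in this assay, at which 3 of the 3 values shown sit: every value shown stands there, so no step between measured compounds can be counted, and compound 1 stands neither better nor worse than the rest of the set on what is shown.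

Compound 4 `CCCCCC#Cc1cn([C@H]2C[C@H](O)[C@@H](CO)O2)c(=O)[nH]c1=O` is the next member, not yet measured. It differs from compound 1 by butyl in place of hydroxy on a saturated chain carbon bound to a triple-bonded carbon: the hydroxy leaves and a butyl enters on the saturated chain carbon bound to the triple-bonded carbon, so the hydroxymethyl becomes a pentyl. Among the measured compounds shown here, with no measured step, the expected step of an at least 1.3-fold lower number from compound 1 to compound 4 (0.12 log units; that floor lies within the scatter) is small and toward stronger inhibition, with a fair chance that the result again ends at a limit. Compound 4 is expected to give about 150000 nM, within 20000 nM to 500000 nM.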

Compound 4, half-maximal inhibitory concentration: > 200000 nM
Compound 4 was reported as a limit (the forecaster's own chance of this, stated with the estimate: 60%); middle value at least 1.3-fold (0.12 log units) from the limit.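

The step from compound 1 to compound 4 cannot be read, because both compounds stand at a limit: the limit of > 200000 nM in this assay, at which 4 of the 4 values shown sit.

The compounds shown leave open whether any member gives a number in this assay rather than a limit, and so whether changing hydroxymethyl to pentyl has any effect there.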